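Adding a Nitrile Group to a Platelet-Activating Factor Acetylhydrolase Series

The compounds below may be only part of what the source reports. "The series", "measured", "known", "first", "only" and "open" are said of these compounds alone.

For the measured compounds named here, compound 1 `FC(F)(F)c1cc(Oc2ccc(COc3ccn4c(-c5cncnc5)cnc4n3)cc2)ccc1Cl` has the higher of the two numbers measured so far. In an assay on isolated protein (plasma) for inhibition of platelet-activating factor acetylhydrolase (Mus musculus), with a stated time of 10 min, tested at 1 uM (on this read-out lower numbers stand for less inhibition and higher numbers for more inhibition at the one concentration tested (going by the name of the read-out)), compound 1 gives 56%, which is the highest of the two numbers. Its only companion, compound 2 `Cn1cc(-c2cnc3nc(OCc4ccc(Oc5ccc(Cl)c(C(F)(F)F)c5)cc4)ccn23)cn1`, differs in one place on the shared core, and in this assay compound 2 gives 28%. The step of a number 28 percentage points lower from compound 1 to compound 2 (beyond the scatter) shows that swapping 1-methyl-1H-pyrazol-4-yl in place of pyrimidin-5-yl on an aromatic carbon lowers the number by a modest but real amount.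

Compound 3 `N#Cc1cc(COc2ccn3c(-c4cncnc4)cnc3n2)ccc1Oc1ccc(Cl)c(C(F)(F)F)c1` keeps the pyrimidin-5-yl group of compound 1 and instead changes a different part of the molecule: cyano in place of hydrogen on an aromatic carbon. The new group sits on an aromatic carbon of a six-membered aromatic ring of carbon only, ortho to a 4-chloro-3-(trifluoromethyl)phenoxy group.

Going by the values given here, no measured step touches this position, so the one known step from compound 1 to compound 2 gives no direct guide. With nothing to suggest otherwise, the change is expected to leave the number close to that of compound 1, within the scatter: the expected step is a number 1 percentage points lower from compound 1 to compound 3 (within the scatter). Compound 3 is therefore estimated to give 55% in this assay, with a range from 35% to 75%.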

Compound 3, a percentage reported as inhibition, at one concentration (the size of the read-out at that concentration, not a potency): 0%
Estimate against measurement, compound 3: 55 percentage points above, and the stated range ends above it.
By their numbers in this assay, from the lowest: compound 3; then compound 2; then compound 1.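

The position on the six-membered aromatic ring of carbon only, ortho to a 4-chloro-3-(trifluoromethyl)phenoxy group, now has its first measurement, and it is far from a silent spot. In this assay, putting cyano in place of hydrogen there gives a number 56 percentage points lower from compound 1 to compound 3 (beyond the scatter), so a change of just 2 heavy atoms at this one place is enough to remove all the inhibition seen at the single concentration tested, with compound 3 at 0% in that read-out. Nothing shown here gives a measured explanation for this loss.

For the compounds shown here, the single cyano example cannot tell whether this position accepts no added group at all or whether the loss belongs to cyano alone; a fluorine atom, a methyl group, a methoxy group or an amine at the same carbon would separate those two readings. Going by these compounds, it also remains open whether cyano at this place would have the same effect with the 1-methyl-1H-pyrazol-4-yl group of compound 2 in place of the pyrimidin-5-yl group.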